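A few compounds are considered here, and "the series" means these few. Any claim that something is new, unique, unknown or untested is made for them only; others in the source may bear on it.

Working notes on the acyl series.

Three compounds of this set have been run so far in a functional assay on the whole organism (Abdomen, strain Swiss) for inhibition, with Mus musculus as the target, with stated times of 30 min, 10 min and 5 min, at a dose of 10 mg/kg by the oral route; on this read-out lower numbers stand for a weaker effect and higher numbers for a stronger effect at the one dose given. Compound 3 `CCC(=O)c1c(C)nn(CCCN2CCN(c3ccc(C)cc3)CC2)c(=O)c1N` gives 9%, the smallest of the three numbers shown, but neither gap to the other two is beyond the scatter. Its nearest neighbour is compound 1 `CCc1nn(CCCN2CCN(c3ccc(C)cc3)CC2)c(=O)c(N)c1C(C)=O`, which in this assay gives 10%; furthest is compound 2 `CC(=O)c1c(C)nn(CCCN2CCN(c3ccc(C)cc3)CC2)c(=O)c1N`, which gives 19%. The two connecting steps are small: a number 9 percentage points higher from compound 1 to compound 2 (within the scatter) and a number 10 percentage points lower from compound 2 to compound 3 (within the scatter).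

Compound 4 `CCCC(=O)c1c(C)nn(CCCN2CCN(c3ccc(C)cc3)CC2)c(=O)c1N` is the next member and differs from compound 3 by methyl in place of hydrogen on a saturated chain carbon, two bonds along the chain from a carbonyl carbon. For the measured compounds named here, the step that bears most directly on it is the one from compound 2 to compound 3, which is the same kind of change one bond closer to the carbonyl carbon and stayed within the scatter; the step from compound 1 to compound 2, a chain change on the other side of the core, did likewise. On that basis no step beyond the scatter is expected in this assay for compound 4, and a number 1 percentage points higher from compound 3 to compound 4 (within the scatter) is the step assumed. Compound 4 is therefore estimated at 10%, with a range from 0% to 22%.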

Compound 4, a percentage reported as inhibition, in the whole organism at one dose (the size of the read-out at that dose, not a potency): 0%
The estimate for compound 4 lay 10 percentage points above the measured number; low and high end bracket the measured number.
By their numbers in this assay, from the lowest: compounds 4, 3, 1 and 2 (each within the scatter of the next, the first and the last beyond it).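

Methyl in place of hydrogen on a saturated chain carbon, two bonds along the chain from a carbonyl carbon, gives on its own in this assay a number 9 percentage points lower from compound 3 to compound 4 (within the scatter), so this single change cannot be told from repeat variation. The larger change gives a number 19 percentage points lower from compound 2 to compound 4 (beyond the scatter), which makes it the one step among those shown to clear the scatter, if only modestly, and two single steps that each stayed within it add up to one that does not. The same change also reads alike in size on a second core: the same change on two cores in this assay, a number 9 percentage points higher (within the scatter) from compound 1 to compound 2 and a number 9 percentage points higher (within the scatter) from compound 4 to compound 3, 0 percentage points apart, within the scatter of two such steps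

As far as these compounds go, whether a longer chain on the carbonyl, a branched chain such as isopropyl or a chain ending in an amine would read any differently from compound 4 at 0% stays open. With the series resting on one dose in this assay, the numbers give the size of the effect at that dose and leave open how the effects of these compounds would compare at any other dose.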